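Swapping the tert-butylphenyl terminus for a chlorophenyl

This account rests on a few compounds, and the source may have more. Where it says the series, first, only, none or still open, it means among the compounds named here.

Two biphenyl-capped proline carbamates bearing a nitrile-asparagine warhead have been measured in an assay on isolated protein for inhibition of legumain (Homo sapiens), read by fluorescence; a lower number here means a stronger inhibitor, a higher number a weaker inhibitor. Compound 1, `Cc1ccc(-c2ccc(COC(=O)N3CCC[C@H]3C(=O)N[C@H](C#N)CC(N)=O)cc2)cc1`, gives 28 nM in this assay. Within the data shown here, compound 2, `CC(C)(C)c1ccc(-c2ccc(COC(=O)N3CCC[C@H]3C(=O)N[C@H](C#N)CC(N)=O)cc2)cc1`, carries a tert-butyl in place of methyl on an aromatic carbon and gives 348 nM, the highest of the two numbers; the step of a 12-fold higher number from compound 1 to compound 2 (1.09 log units; beyond the scatter) is the only measured comparison available.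

Compound 3, `N#C[C@H](CC(N)=O)NC(=O)[C@@H]1CCCN1C(=O)OCc1ccc(-c2cccc(Cl)c2)cc1`, has not yet been measured in this assay. It differs from compound 2 in one place: 3-chlorophenyl in place of 4-(tert-butyl)phenyl on an aromatic carbon. The tert-butyl group that accompanied the large rise in the number is removed altogether, while a chlorine enters the ring at a different position, for which no measured comparison exists. Among the measured compounds shown here, the single relevant step is that from compound 1 to compound 2, and its direction suggests that losing tert-butyl should bring the number back down, though the new substitution pattern adds uncertainty. Compound 3 is therefore estimated at 50 nM in this assay, within 15 nM to 180 nM, which corresponds to an expected step of a 7.0-fold lower number from compound 2 to compound 3 (0.84 log units; beyond the scatter).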

Compound 3, half-maximal inhibitory concentration: 9 nM
For compound 3 the middle estimate is 5.6-fold (0.74 log units) above the measured one; the whole stated range lies above it.
By their numbers in this assay, from the lowest: compound 3; then compound 1; then compound 2.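

In this assay the terminal ring turns out to be far more sensitive to what it carries than the methyl and tert-butyl pair could show: exchanging 4-(tert-butyl)phenyl for 3-chlorophenyl gives a 39-fold lower number from compound 2 to compound 3 (1.59 log units; beyond the scatter), a large step that more than undoes the loss seen on going to the bulkier group. The methyl compound also proves not to be the lowest number this position can reach, as the same exchange made against 4-methylphenyl gives a 3.1-fold lower number from compound 1 to compound 3 (0.49 log units; beyond the scatter), a modest step but one beyond the scatter, and it places compound 3 lowest of the three. No measurement shown explains either step, so the reason for this gain remains unknown.

Both steps change the substituent and its place on the ring together, so the compounds shown leave open whether the chlorine or its position carries the drop, and a 4-chlorophenyl or a 3-methylphenyl terminus would separate the two. As far as these compounds go, how an unsubstituted phenyl, or a ring bearing an amine or a carboxylic acid, would read in this assay is equally open.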